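Replacing an ester linker with a phenethyl ether

This account rests on a few compounds, and the source may have more. Where it says the series, first, only, none or still open, it means among the compounds named here.

Of the compounds shown here, three sharing one core have been measured in a functional assay on HEK293 cells for agonist activity at G-protein coupled receptor 39 (Homo sapiens), read by scintillation proximity assay and inositol phosphate accumulation, with a stated time of 75 min; a higher number here means that more compound is needed for the effect, a lower number that less compound is needed. Compound 1 `Cc1cc(C)n(CCOC2CC(=O)Nc3c2c(C)nn3-c2ncnc3nc[nH]c23)n1` gives 2000 nM. Compound 2 `Cc1nn(-c2ncnc3nc[nH]c23)c2c1C(OCc1ccc(F)cc1)CC(=O)N2` gives 126 nM, and compound 3 `Cc1nn(-c2ncnc3nc[nH]c23)c2c1C(OC(=O)c1ccc(F)cc1)CC(=O)N2` gives 245 nM. The change a 16-fold lower number from compound 1 to compound 2 (1.20 log units; beyond the scatter) was large, and an 8.2-fold lower number from compound 1 to compound 3 (0.91 log units; beyond the scatter) was modest; between the two fluorinated compounds, a 1.9-fold higher number from compound 2 to compound 3 (0.29 log units; within the scatter) stays within the scatter. Compound 3 therefore stands second of the three numbers, close to compound 2 and well apart from compound 1.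

Compound 4 `Cc1nn(-c2ncnc3nc[nH]c23)c2c1C(OCCc1ccccc1)CC(=O)N2` differs from compound 3 by phenethyl in place of (4-fluorophenyl)carbonyl on an oxygen on a saturated carbon. For the measured compounds named here, the step that bears most on this is the comparison of an ether with an ester, a 1.9-fold higher number from compound 2 to compound 3 (0.29 log units; within the scatter), which showed no change beyond the scatter; no measured step shows what removing the fluorine does or what lengthening the link by one carbon does. Compound 4 is therefore expected to sit near compound 3, with the step of a 1.2-fold lower number from compound 3 to compound 4 (0.09 log units; within the scatter) estimated to be within the scatter. The estimate for compound 4 is 200 nM, with a range from 60 nM to 700 nM.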

Compound 4, half-maximal effective concentration: 40 nM
The estimate for compound 4 lay 5.0-fold (0.70 log units) above the measured number; measured number below the stated range.
By their numbers in this assay, from the lowest: compound 4; then compounds 2 and 3 (each within the scatter of the next); then compound 1.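

In this assay, the group on the oxygen does change the result, which the ether and ester comparison had not shown: the phenethyl group gives a 6.1-fold lower number from compound 3 to compound 4 (0.79 log units; beyond the scatter) and a 3.2-fold lower number from compound 2 to compound 4 (0.50 log units; beyond the scatter), both beyond the scatter. The second step removes the fluorine and adds a carbon to the link together, so the two changes cannot be separated. On the same chain, phenyl in place of 3,5-dimethyl-1H-pyrazol-1-yl gives a 50-fold lower number from compound 1 to compound 4 (1.70 log units; beyond the scatter), making compound 4 the one that needs the least compound of the four, and no supporting data are available to explain these differences.

The compounds shown leave open whether 4-fluorophenethyl would match compound 4, which would isolate the role of the fluorine. They also leave open how a longer chain, such as 3-phenylpropyl, or an amine at the end of the chain would behave.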